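The source may hold more compounds than are shown below. What is called first, only, known or untested is meant among the compounds shown, and "the series" means these compounds.

Measured so far:
Compound 1 `O=C(N1CCC=C[C@@H]1COCc1ccccc1)n1ccc(-c2ccc(Br)cc2)n1`: in an assay on HEK293 cells for inhibition of Monoacylglycerol lipase ABHD6 (Homo sapiens), read by fluorescence (a lower number here means a stronger inhibitor, a higher number a weaker inhibitor), compound 1 gives > 10000 nM, a limit of the assay.
Compound 2 `O=C(N1CCC=C[C@@H]1COCc1ccccc1)n1cnc(-c2ccc(Br)cc2)c1`: in this assay compound 2 gives > 10000 nM, again a limit of the assay.
Compound 3 `O=C(N1CCC=C[C@@H]1COCc1ccccc1)n1ccc(-c2ccc(-c3ccccc3)cc2)n1`: in this assay compound 3 gives > 10000 nM, also a limit of the assay.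

Compound 1 and compound 2 share the same atoms joined differently; the difference between the two cores is not broken down here. From compound 1 to compound 3 the change is phenyl in place of bromo on an aromatic carbon, and the step is a step that the two limits leave unreadable from compound 1 to compound 3, because the limit of > 10000 nM in this assay, at which 3 of the 3 values shown sit, holds both ends of it.

Compound 4 `O=C(N1CCC=C[C@@H]1COCc1ccccc1)n1cnc(-c2ccc(-c3ccccc3)cc2)c1` has not yet been measured. It stands to compound 2 as compound 3 stands to compound 1: the change is phenyl in place of bromo on an aromatic carbon, the same change at the same place. Among the measured compounds shown here, since the first instance of this change left compound 1 and compound 3 at the limit, the step from compound 2 to compound 4 is expected to be a step that the limit leaves unreadable from compound 2 to compound 4, resting on a step that the two limits leave unreadable from compound 1 to compound 3. Compound 4 is therefore estimated at 20000 nM, most likely reported only as a limit, within 8000 nM to 100000 nM.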

Compound 4, half-maximal inhibitory concentration: > 10000 nM
Compound 4: a limit, no number (the forecaster's own chance of this, stated with the estimate: 85%); the middle value does not contradict the limit.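

No new step can be read from compound 2 to compound 4, where phenyl stands in place of bromo, because both compounds give only a limit and no number: the limit of > 10000 nM in this assay, at which 4 of the 4 values shown sit. The compounds shown leave open how far any of them inhibits at all, and whether either the phenyl-for-bromo change or the difference between the two cores alters that inhibition.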